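This account rests on a few compounds, and the source may have more. Where it says the series, first, only, none or still open, it means among the compounds named here.

Compound 1, `COC(=O)c1sc2cc(-c3ccsc3)cnc2c1N`, was tested in a functional assay on MCF7 cells (Homo sapiens) for inhibition, read by sulforhodamine B assay, with a stated time of 48 h (on this read-out lower numbers stand for stronger inhibition of growth and higher numbers for weaker inhibition of growth), and gave 12700 nM. Two other compounds share its core. Compound 2, `COC(=O)c1sc2cc(-c3cnc4ccccc4c3)cnc2c1N`, gave 9800 nM, and compound 3, `COC(=O)c1sc2cc(-c3cc(OC)cc(OC)c3)cnc2c1N`, gave 56600 nM. Among these three numbers compound 1 sits second highest; its gap to compound 2 lies within the scatter of repeated measurements, while its gap to compound 3 lies beyond it. Compound 4, `COC(=O)c1sc2cc(-c3cccc(N)c3)cnc2c1N`, is still to be measured. Its change from compound 1 is 3-aminophenyl in place of thiophen-3-yl on an aromatic carbon. Within the data shown here, no measured pair shows this exact change, so the expectation rests only on the spread of the three values. A step of a 1.2-fold lower number from compound 1 to compound 4 (0.06 log units; within the scatter) is expected, with no direction beyond the scatter. Compound 4 is thus expected to give about 11000 nM, between 4000 nM and 35000 nM.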

Compound 4, concentration for 50% growth inhibition: > 150000 nM
Compound 4: no number, only a limit; the forecaster's own chance of this, stated with the estimate: 5%; at least 13-fold (1.13 log units) between middle value and limit.
By their numbers in this assay, from the lowest: compounds 2 and 1 (each within the scatter of the next); then compound 3. At a limit, above all of these: compound 4.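

Compound 4 has no number here, only a limit of the assay: the limit of > 150000 nM in this assay, at which 1 of the 4 values shown sits. Among these compounds, this position on the shared core is therefore more sensitive than the earlier compounds suggested, as 3-aminophenyl in place of thiophen-3-yl gives an at least 11-fold higher number from compound 1 to compound 4 (1.07 log units; beyond the scatter). Compound 3, which also carries a phenyl ring at this position, gives 56600 nM, so a phenyl ring alone does not account for the step. The compounds shown leave open whether the amino group itself accounts for the step: a plain phenyl or a 3-hydroxyphenyl group here would test that.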